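A few compounds are considered here, and "the series" means these few. Any claim that something is new, unique, unknown or untested is made for them only; others in the source may bear on it.

In a toxicity assay on HeLa cells (Homo sapiens) for cytotoxicity, read by MTT assay, with a stated time of 24 h (on this read-out lower numbers stand for stronger inhibition and higher numbers for weaker inhibition), compound 1 `Cc1ncc([N+](=O)[O-])n1CC(O)CSC(=S)N1CCN(c2ccccc2)CC1` gives only a limit of the assay, > 5000000 nM. Compound 2 `Cc1ncc([N+](=O)[O-])n1CC(O)CSC(=S)N(C)C` likewise reaches only a limit, > 5000000 nM. Compound 3 `CCN(C)C(=S)SCC(O)Cn1c([N+](=O)[O-])cnc1C` gives 4150000 nM, and the step of an at least 1.2-fold lower number from compound 2 to compound 3 (0.08 log units; that floor lies within the scatter) is too small to read. Since two of the three values sit at the same limit (the limit of > 5000000 nM in this assay, at which 2 of the 3 values shown sit), compound 1 cannot be set apart from compound 2, and compound 3 sits close by. Compound 4 `CCCCN1CCN(C(=S)SCC(O)Cn2c([N+](=O)[O-])cnc2C)CC1` differs from compound 1 by butyl in place of phenyl on an amine nitrogen in a ring. For the measured compounds named here, no measured step touches this position, and the one measured step stays within the scatter, so no change beyond the scatter is expected in this assay. Compound 4 is therefore expected to give about 5000000 nM, between 1500000 nM and 20000000 nM, the estimated step of a number no higher from compound 1 to compound 4 (the limit leaves the size open) being small and most likely ending at the limit again.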

Compound 4, half-maximal inhibitory concentration: 1910000 nM
Beside the measured number, compound 4's estimate is 2.6-fold (0.42 log units) above it; low and high end bracket the measured number.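

Butyl in place of phenyl on this ring nitrogen registers in this assay: the change gives an at least 2.6-fold lower number from compound 1 to compound 4 (0.41 log units; beyond the scatter). Unlike the one earlier step, this step lies beyond the scatter, so the group on this nitrogen can shift the number. Its full size stays unknown because compound 1 sits at a limit and not at a measured number: the limit of > 5000000 nM in this assay, at which 2 of the 4 values shown sit.

From the compounds shown here alone, whether a longer chain, a benzyl group or a chain bearing a carboxylic acid on this nitrogen would lower the number further stays open. So does whether losing the ring or gaining the chain matters more.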